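Halogens return to the carbonyl aryl: an expected weakening

The source may report more compounds than this note shows. Statements on the series, on what has been measured and on what is new or still open speak of the compounds shown alone.

Of the compounds shown here, three have been measured in a functional assay on HT-29 cells (Homo sapiens) for cytotoxicity, read by sulforhodamine B assay, with a stated time of 48 h, tested at 10 uM; a higher number here means a weaker effect of the compound at the concentration tested, a lower number a stronger effect. Compound 1 `COc1cc(-c2cc(/C=C/C(=O)c3ccc(Cl)c(Cl)c3)[nH]n2)cc(OC)c1OC` gives 53%. Compound 2 `COc1ccc(C(=O)/C=C/c2cc(-c3cc(OC)c(OC)c(OC)c3)n[nH]2)cc1OC` gives -94%, and compound 3 `COc1ccc(C(=O)/C=C/c2cc(-c3cc(OC)c(OC)c(OC)c3)n[nH]2)cc1` gives -58%. Compound 3 therefore stands second highest of the three numbers, with compound 2 the nearest and compound 1 the furthest away. Among the measured steps, a number 111 percentage points lower from compound 1 to compound 3 (beyond the scatter), a number 147 percentage points lower from compound 1 to compound 2 (beyond the scatter), and a number 36 percentage points higher from compound 2 to compound 3 (beyond the scatter).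

Compound 4 `COc1cc(-c2cc(/C=C/C(=O)c3ccc(F)c(F)c3)[nH]n2)cc(OC)c1OC` differs from compound 3 in one place: 3,4-difluorophenyl in place of 4-methoxyphenyl on a carbonyl carbon. Among the compounds with values here, the step that bears most on this is the one between compound 1 and compound 3, where the aryl on the carbonyl carbon went from a dichlorinated to a methoxylated ring and the number fell far; compound 4 carries a difluorinated ring at that position, so a reversal of a comparable size is expected, with the number rising well beyond the scatter. No halogen other than chlorine has been measured here, so the size is uncertain. Compound 4 is estimated at 20% in this assay, between -35% and 60%, a change of a number 78 percentage points higher from compound 3 to compound 4 (beyond the scatter).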

Compound 4, a percentage reported as activity, at one concentration (the size of the read-out at that concentration, not a potency): -24%
The estimate for compound 4 lay 44 percentage points above the measured number, within the range that was stated.
By their numbers in this assay, from the lowest: compound 2; then compound 3; then compound 4; then compound 1.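

In this assay, the two dihalogenated rings on the carbonyl carbon are not interchangeable: 3,4-difluorophenyl in place of 3,4-dichlorophenyl gives a number 77 percentage points lower from compound 1 to compound 4 (beyond the scatter), and compound 4 stays negative at -24%. Both methoxylated rings still give lower numbers than the difluorinated ring, with a number 34 percentage points higher from compound 3 to compound 4 (beyond the scatter) and a number 70 percentage points higher from compound 2 to compound 4 (beyond the scatter), so among these four compounds the two methoxylated rings lie lowest and the fluorinated ring falls in the gap between them and the chlorinated ring. Nothing available here accounts for this order.

The compounds shown leave open where an aryl ring carrying a trifluoromethyl group, a dimethylamino group or bromine would fall at this carbonyl carbon. They also leave open whether the same order holds at other concentrations or in other cell lines.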